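This account rests on a few compounds, and the source may have more. Where it says the series, first, only, none or still open, it means among the compounds named here.

In a functional assay on OCI-Ly3 cells (Homo sapiens) for antiproliferative activity (on this read-out lower numbers stand for an effect already at smaller amounts and higher numbers for an effect only at larger amounts of compound), compound 1 (`Cc1c(NC(=O)Nc2cnc(-n3nccn3)c(Cl)c2)cnc2ccc(Br)cc12`) gives 12900 nM and compound 2 (`Cc1c(NC(=O)Nc2cnc(-n3nccn3)c(Cl)c2)cnc2ccccc12`) gives 7170 nM while compound 3 (`O=C(Nc1cnc(-n2nccn2)c(Cl)c1)Nc1cnc2ccc(F)cc2c1C1CC1`) gives 720 nM on the same read-out. Compound 2 therefore lies within the scatter of compound 1 at the upper end of the numbers, and compound 3 stands clearly lower than compound 2.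

The next change leads to compound 4 (`CCOC(C)c1c(NC(=O)Nc2cnc(-n3nccn3)c(Cl)c2)cnc2ccccc12`), with 1-ethoxyethyl in place of methyl on an aromatic carbon opposite the ring nitrogen: 1-ethoxyethyl in place of methyl on an aromatic carbon is the full count.

Among the compounds with values here, the only measured step, a 1.8-fold lower number from compound 1 to compound 2 (0.26 log units; within the scatter), lies within the scatter. It is hydrogen in place of bromo at a different place, so it says little about this change. Compound 3 lacks the methyl of compound 2 but differs in more than one place, so no clean step can be read from it. Compound 3 with 720 nM only shows that much lower numbers occur among these compounds without that methyl.

On that thin basis a lower number is expected, with the estimated change being a 4.8-fold lower number from compound 2 to compound 4 (0.68 log units; beyond the scatter) and the uncertainty wide. For compound 4 the estimated value is 1500 nM with a range from 300 nM to 8000 nM on current evidence.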

Compound 4, half-maximal effective concentration: 1530 nM
Compound 4: middle estimate off by 1.0-fold (0.01 log units), on the low side; the range from low to high includes it.
By their numbers in this assay, from the lowest: compound 3; then compound 4; then compounds 2 and 1 (each within the scatter of the next).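

In this assay, within the data shown here, the aromatic carbon opposite the ring nitrogen is the first place where a single change moves the read-out beyond the scatter: a 4.7-fold lower number from compound 2 to compound 4 (0.67 log units; beyond the scatter) with 1-ethoxyethyl in place of methyl. Among these compounds, the only earlier single-place step, hydrogen in place of bromo, stayed within the scatter, so compound 4 adds the first clean evidence that this position responds to what it carries. It also shows that the larger group, with its 5 heavy atoms and 1 hydrogen-bond acceptor, is accepted here with a lower number and no loss, although nothing on hand bears on the reason for this step.

The compounds shown do not separate the contribution of the oxygen in 1-ethoxyethyl from that of the chain itself, a question that a plain butyl chain at the same place would address. They also leave open how an amine or a carboxylic acid at the end of such a chain would read out, and whether the same step holds with the bromo of compound 1 on the core.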